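The source may report more compounds than this note shows. Statements on the series, on what has been measured and on what is new or still open speak of the compounds shown alone.

Working notes on the series: two compounds have half-lives so far in an ADME assay on microsomes from liver (Rattus norvegicus) for metabolic stability, read by LC-MS, using NADPH, with stated times of 10 min and 60 min; on this read-out lower numbers stand for a shorter-lived compound and higher numbers for a longer-lived compound. There compound 1 (`CN1CCN(c2cc(CN(C)C3CCCc4cccnc43)nc(N)n2)CC1`) gives 0.054 h and compound 2 (`CCN1CCN(c2cc(CN(C)[C@H]3CCCc4cccnc43)nc(C)n2)CC1`) gives 0.019 h as the lower of the two numbers, with the gap beyond the usual scatter. Going by the values given here, these two differ in more than one place, so no single-place step is available as a guide. Compound 3 (`Cc1nc(CN(C)[C@H]2CCCc3cccnc32)cc(N2C[C@@H](C)N(C)[C@@H](C)C2)n1`) carries 3,4,5-trimethylpiperazin-1-yl in place of the 4-ethylpiperazin-1-yl of compound 2 on an aromatic carbon, and 3,4,5-trimethylpiperazin-1-yl in place of 4-ethylpiperazin-1-yl on an aromatic carbon gives the count of that change. The expectation therefore rests on the structural change alone. A small rise is expected, with the estimate at a 1.6-fold higher number from compound 2 to compound 3 (0.20 log units; within the scatter) and most likely not beyond the scatter. In this assay compound 3 is estimated at 0.03 h with an expected range of 0.012 h to 0.08 h for the half-life.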

Compound 3, half-life: < 0.0167 h
Compound 3 was reported as a limit (the forecaster's own chance of this, stated with the estimate: 10%); middle value at least 1.7-fold (0.25 log units) from the limit.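

In this assay, the series now has its first single-place step, at the aromatic carbon of the six-membered aromatic ring with 2 nitrogen: 3,4,5-trimethylpiperazin-1-yl in place of 4-ethylpiperazin-1-yl gives an at least 1.1-fold lower number from compound 2 to compound 3 (0.05 log units; that floor lies within the scatter). The half-life of compound 3 is a limit and not a number, so the step has a floor but no measured size: the limit of < 0.0167 h in this assay, at which 1 of the 3 values shown sits. Even so, this change at this position gives no sign of a longer half-life, while a true fall in half-life remains unproven with the floor inside the scatter.

From the compounds shown here alone, whether a morpholine or an open-chain amine at this position would give a half-life clear of the limit remains open. Going by these compounds, compound 1 and compound 2 differ in more than one place, so the separate effect of each of their differences also remains open.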